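The compounds below may be only part of what the source reports. "The series", "measured", "known", "first", "only" and "open" are said of these compounds alone.

Measured compounds:
compound 1, `C#CCNC1CCc2c(SCCc3ccc(C)cc3)cccc21`, 25800 nM
compound 2, `C#CCNC1CCc2c(SCCc3cccc(C(F)(F)F)c3)cccc21`, 3720 nM
compound 3, `C#CCNC1CCc2c(SCCc3cccc(F)c3)cccc21`, 4300 nM

In an assay on isolated protein for inhibition of Amine oxidase [flavin-containing] B (Homo sapiens) (a higher number here means a weaker inhibitor, a lower number a stronger inhibitor), compound 3 stands second highest of the three numbers. Its nearest neighbour is compound 2: the step of a 1.2-fold higher number from compound 2 to compound 3 (0.06 log units; within the scatter) is within the scatter, so the two cannot be ordered. Its furthest is compound 1, with the step of a 6.0-fold lower number from compound 1 to compound 3 (0.78 log units; beyond the scatter) beyond the scatter.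

Compound 4, `C#CCNC1CCc2c(SCCc3ccc(Cl)c(Cl)c3)cccc21`, differs from compound 3 as follows: 3,4-dichlorophenyl in place of 3-fluorophenyl on a saturated chain carbon, two bonds along the chain from a sulfur. For the measured compounds named here, two measured steps bear on this. The step of a 6.0-fold lower number from compound 1 to compound 3 (0.78 log units; beyond the scatter) shows that a halogen-bearing ring in place of the methyl-bearing ring lowered the number by a modest amount; the step of a 1.2-fold higher number from compound 2 to compound 3 (0.06 log units; within the scatter) shows that swapping one halogen-containing group for another on that ring changed nothing beyond the scatter. Going by the values given here, a ring carrying two chlorines has no direct precedent, so the size of the step is uncertain; the expectation in this assay is a step no larger than the scatter or slightly downward, a 1.5-fold lower number from compound 3 to compound 4 (0.19 log units; within the scatter). Compound 4 is therefore estimated at 2800 nM, with a range from 900 nM to 9000 nM.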

Compound 4, half-maximal inhibitory concentration: 3850 nM
The estimate for compound 4 lay 1.4-fold (0.14 log units) below the measured number; the range from low to high includes it.
By their numbers in this assay, from the lowest: compounds 2, 4 and 3 (each within the scatter of the next); then compound 1.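

In this assay, the step of a 1.1-fold lower number from compound 3 to compound 4 (0.05 log units; within the scatter) shows that at this position, on a saturated chain carbon, two bonds along the chain from a sulfur, 3,4-dichlorophenyl cannot be told apart from 3-fluorophenyl, even with chlorine replacing fluorine and a second halogen added. For the compounds shown here, the step of a 6.7-fold lower number from compound 1 to compound 4 (0.83 log units; beyond the scatter) shows that the separation of compound 1 from the halogen-bearing rings also holds for a ring with a substituent at its 4-position, which the earlier compounds did not show. Nothing measured here explains this insensitivity among the halogen-bearing rings.

From the compounds shown here alone, whether the methyl group itself sets compound 1 apart remains open, and unsubstituted phenyl, 4-chlorophenyl or 3-methylphenyl would bear on that. Going by these compounds, the effect of a ring carrying an amine or a carboxylic acid, or of a longer chain to the sulfur, also remains open.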